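Chain extension from compound 2 to compound 3

This account rests on a few compounds, and the source may have more. Where it says the series, first, only, none or still open, it means among the compounds named here.

Measured in a functional assay, with stated times of 30 s and 6 min, in the presence of a further agent that is not named here; a higher number here means a weaker inhibitor, a lower number a stronger inhibitor:
- compound 1 `CCCCCCCCCCCCCCCCOc1cc(OC)c(Br)cc1C(C)=O`: 1800000 nM
- compound 2 `CCCCCCCCCCCCOc1cc(OC)ccc1C(C)=O`: 28500000 nM

Compound 2 (28500000 nM) holds the higher of the two numbers, and its gap to compound 1 (1800000 nM) lies beyond the scatter. Compound 3 `CCCCCCCCCCCCCCCCOc1cc(OC)ccc1C(C)=O` differs from compound 2 by butyl in place of hydrogen on a saturated chain carbon, ten or more bonds along the chain from an oxygen on an aromatic ring (the same difference reads as methyl to pentyl). For the measured compounds named here, no measured pair isolates this change, so the expectation is tentative. Going by the values given here, the only guide is compound 1 (1800000 nM), and a lower number beyond the scatter is expected in this assay. The estimated step is a 4.1-fold lower number from compound 2 to compound 3 (0.61 log units; beyond the scatter) (expected toward a stronger inhibitor). For compound 3 the estimate is 7000000 nM (expected range 1500000 nM to 30000000 nM).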

Compound 3, half-maximal inhibitory concentration: 39400000 nM
Beside the measured number, compound 3's estimate is 5.6-fold (0.75 log units) below it, outside the stated range (above it).
By their numbers in this assay, from the lowest: compound 1; then compounds 2 and 3 (each within the scatter of the next).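

In this assay, butyl in place of hydrogen on the saturated chain carbon gives a 1.4-fold higher number from compound 2 to compound 3 (0.14 log units; within the scatter), so this chain extension does not separate the two compounds. At the same chain length, hydrogen in place of bromo on an aromatic carbon gives a 22-fold higher number from compound 1 to compound 3 (1.34 log units; beyond the scatter), making this aromatic carbon, not the chain end, the place where the series responds. No evidence on the cause of either step is available.

Open, from the compounds shown here alone, is whether chloro on that aromatic carbon would match bromo, and whether a longer chain would stay within the scatter.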